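The source may report more compounds than this note shows. Statements on the series, on what has been measured and on what is new or still open speak of the compounds shown alone.

Measured compounds:
Compound 1, `Cc1ccc2c(c1)c([N+](=O)[O-])cc[n+]2[O-]`, 1.24.
Compound 2, `O=[N+]([O-])c1ccc2c(c1)c([N+](=O)[O-])cc[n+]2[O-]`, 0.9.

For the measured compounds named here, in a physicochemical assay for lipophilicity (on this read-out lower numbers stand for lower lipophilicity and higher numbers for higher lipophilicity), compound 2 stands lowest of the two numbers, with compound 1 as its nearest neighbour; the one measured step, a number 0.34 log units lower from compound 1 to compound 2 (beyond the scatter), is a modest drop beyond the scatter.

Compound 3, `O=C(O)c1ccc2c(c1)c([N+](=O)[O-])cc[n+]2[O-]`, differs from compound 2 by carboxy in place of nitro on an aromatic carbon. Going by the values given here, no measured step involves a carboxy group, so the step from compound 1 to compound 2 bears on the new change only loosely: it shows that replacing one group by another at this place shifts this assay by a modest amount, and nothing more. For compound 3 a small move downward is therefore expected, which may well lie within the scatter, a number 0.20 log units lower from compound 2 to compound 3 (within the scatter). Compound 3 is estimated at 0.7 in this assay, within a range of 0 to 1.2.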

Compound 3, partition coefficient: 0.42
Beside the measured number, compound 3's estimate is 0.28 log units above it; measured number inside the range.
By their numbers in this assay, from the lowest: compound 3; then compound 2; then compound 1.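

In this assay this place, on an aromatic carbon meta to a fused ring and para to a fused ring, separates even two groups of equal size by count: nitro and carboxy each have 3 heavy atoms and no net charge, yet the exchange gives a number 0.48 log units lower from compound 2 to compound 3 (beyond the scatter). Set against methyl, carboxy gives a number 0.82 log units lower from compound 1 to compound 3 (beyond the scatter), so compound 3 holds the lowest number of the three, with its steps to both others beyond the scatter. The exchange of nitro for carboxy also changes the hydrogen-bond counts, from 0 donors and 2 acceptors to 1 donor and 1 acceptor.

Where an amine, an amide or a longer chain would fall at this place remains open. No measured evidence shown here accounts for the order of these three groups.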